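A few compounds are considered here, and "the series" means these few. Any claim that something is new, unique, unknown or untested is made for them only; others in the source may bear on it.

In a functional assay on B16-F10 cells (Mus musculus) for inhibition, read by MTT assay, with a stated time of 72 h (a lower number here means a stronger inhibitor, a higher number a weaker inhibitor), compound 1 `CC1(C)CC(NC(=S)Nc2ccc(C#N)cc2)c2cc(F)ccc2O1` gives 5000 nM and compound 2 `CC1(C)CC(NC(=S)Nc2cccc(C#N)c2)c2cc(F)ccc2O1` gives 35000 nM. Compound 2 therefore has the higher of the two numbers and is the weaker inhibitor of the pair. Compound 3 `CC1(C)CC(NC(=S)Nc2cccc(C#N)c2)c2cc(Cl)ccc2O1` keeps the 3-cyanophenyl group of compound 2 and carries chloro in place of fluoro on an aromatic carbon. Among the measured compounds shown here, the only measured step, a 7.0-fold higher number from compound 1 to compound 2 (0.85 log units; beyond the scatter), is modest but beyond the scatter. It comes from 3-cyanophenyl in place of 4-cyanophenyl, so it bears on the halogen change only indirectly. For the measured compounds named here, no measured pair shows a halogen exchange, so no step beyond the scatter is expected in this assay. The step estimated on this basis is a 1.4-fold lower number from compound 2 to compound 3 (0.15 log units; within the scatter). For compound 3 the estimated value is 25000 nM, with an expected range of 9000 nM to 70000 nM.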

Compound 3, half-maximal inhibitory concentration: 6000 nM
The estimate for compound 3 lay 4.2-fold (0.62 log units) above the measured number; the measured number lies below the stated range.
By their numbers in this assay, from the lowest: compounds 1 and 3 (each within the scatter of the next); then compound 2.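

Chloro in place of fluoro on this aromatic carbon gives a 5.8-fold lower number from compound 2 to compound 3 (0.77 log units; beyond the scatter) in this assay. Among the compounds shown here, the earlier compounds showed only that the number responds to the place of the nitrile on the phenyl group, whereas this pair shows that it also responds to the exchange of one halogen for another on the fused system of two rings, with the 3-cyanophenyl group kept. No evidence at hand accounts for this step.

As far as these compounds go, whether chloro lowers the number to a similar extent alongside the 4-cyanophenyl group of compound 1 remains open, since this exchange is seen in a single pair. Also open, from the compounds shown here alone, is how bromo, methyl or methoxy on the same aromatic carbon would compare with chloro and fluoro.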